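Replacing hydroxymethyl with 3-methyl-1,2,4-oxadiazol-5-yl

A few compounds are considered here, and "the series" means these few. Any claim that something is new, unique, unknown or untested is made for them only; others in the source may bear on it.

Values measured so far in an ADME assay on the whole organism (Rattus norvegicus, strain Fischer 344) for pharmacokinetics, with a stated time of 8 h, at a dose of 3 mg/kg by the oral route; a lower number here means less compound in the circulation, a higher number more compound in the circulation at the dose given:
Compound 1 (`NC(=O)c1sc2nccc(N3CCC[C@H](COCC(=O)N4CCOCC4)C3)c2c1N`): 756 ng.h/mL
Compound 2 (`NC(=O)c1sc2nccc(N3CCC[C@H](COCCO)C3)c2c1N`): 320 ng.h/mL

Of these two compounds, compound 2 holds the lower number. Within the data shown here, the one measured step (a 2.4-fold lower number from compound 1 to compound 2 (0.37 log units; beyond the scatter)) is modest and lies beyond the scatter. It exchanged (morpholin-4-yl)carbonyl for hydroxymethyl on a saturated chain carbon bound to an oxygen on a saturated carbon.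

Compound 3 (`Cc1noc(COC[C@H]2CCCN(c3ccnc4sc(C(N)=O)c(N)c34)C2)n1`) differs from compound 2 at that same place, with 3-methyl-1,2,4-oxadiazol-5-yl in place of hydroxymethyl (3-methyl-1,2,4-oxadiazol-5-yl in place of hydroxymethyl on a saturated chain carbon bound to an oxygen on a saturated carbon). Among the measured compounds shown here, the only guide is that compound 1 (756 ng.h/mL) shows a higher number than the hydroxymethyl compound, so a larger group there has been seen once with more compound in the circulation. That is a single comparison, and the incoming group has no measurement of its own, so a result within the scatter would not be surprising. A modest rise in this assay is therefore expected (a 1.7-fold higher number from compound 2 to compound 3 (0.24 log units; within the scatter)). Compound 3 is estimated at 550 ng.h/mL (range 180 ng.h/mL to 1600 ng.h/mL).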

Compound 3, area under the concentration-time curve: 563 ng.h/mL
Compound 3: the middle estimate sits 1.0-fold (0.01 log units) below what was measured, and the stated range covers the measured number.
By their numbers in this assay, from the lowest: compounds 2, 3 and 1 (each within the scatter of the next, the first and the last beyond it).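

In this assay, the change to the 3-methyl-1,2,4-oxadiazol-5-yl group gives a 1.8-fold higher number from compound 2 to compound 3 (0.25 log units; within the scatter). Set against the morpholin-4-yl carbonyl group, it gives a 1.3-fold lower number from compound 1 to compound 3 (0.13 log units; within the scatter), so compound 3 cannot be told apart from either of the earlier compounds, even though those two stand apart from each other (a 2.4-fold lower number from compound 1 to compound 2 (0.37 log units; beyond the scatter)). The position on a saturated chain carbon bound to an oxygen on a saturated carbon has now taken a second group larger than hydroxymethyl, this one an aromatic ring with 0 hydrogen-bond donors, but the rise seen once with compound 1 is neither confirmed beyond the scatter nor contradicted by compound 3. Nothing available explains why the number in compound 3 falls where it does.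

The three compounds leave open how a simple amine such as dimethylamino, a carboxylic acid or a longer chain would fare at this place. They also leave open whether a repeat measurement would resolve compound 3 from compound 1 or compound 2, and a single area under the curve does not show which stage of the compound's passage through the rat sets these numbers.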